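The source may hold more compounds than are shown below. What is called first, only, known or untested is meant among the compounds shown, and "the series" means these compounds.

Measured so far:
Compound 1 `O=C1C(N2CCCCC2)=CC(=O)c2c1nc1n2[C@H]2OC[C@@H](O)[C@H]2OC1`: in a functional assay on HeLa cells (Homo sapiens) for inhibition, read by sulforhodamine B assay (on this read-out higher numbers stand for weaker inhibition and lower numbers for stronger inhibition), compound 1 gives only a limit of the assay, > 16000 nM.
Compound 2 `O=C1C=C(Nc2ccccc2)C(=O)c2c1nc1n2[C@H]2OC[C@@H](O)[C@H]2OC1`: in this assay compound 2 gives 5620 nM.
Compound 3 `CCOc1ccc(NC2=CC(=O)c3nc4n(c3C2=O)[C@H]2OC[C@@H](O)[C@H]2OC4)cc1`: in this assay compound 3 gives 3110 nM.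

Compound 1 thus stands apart from the other two: its result is a limit rather than a number, as recorded by the limit of > 16000 nM in this assay, at which 1 of the 3 values shown sits. Among the measured compounds shown here, compounds 2 and 3 both gave numbers, and the single measured step between them, a 1.8-fold lower number from compound 2 to compound 3 (0.26 log units; within the scatter), shows that ethoxy in place of hydrogen on an aromatic carbon changed nothing beyond the scatter.

The compound still to be measured is compound 4 `O=C1C(Nc2cccc(F)c2)=CC(=O)c2c1nc1n2[C@H]2OC[C@@H](O)[C@H]2OC1`. It differs from compound 1 in one place: (3-fluorophenyl)amino in place of piperidin-1-yl on a double-bonded ring carbon. Compounds 2 and 3 carry a related amino-linked aromatic ring on that same double-bonded ring carbon, so their numbers are the closest guide, while the step from compound 1 itself cannot be sized, since compound 1 gave only a limit. As far as these compounds go, compound 4 is therefore expected to land near compounds 2 and 3, with an expected step of an at least 3.5-fold lower number from compound 1 to compound 4 (0.55 log units; beyond the scatter) toward stronger inhibition whose exact size remains open. For compound 4 the estimate in this assay is 4500 nM, within a range from 1500 nM to 14000 nM.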

Compound 4, half-maximal inhibitory concentration: > 8000 nM
Compound 4: no number, only a limit; the forecaster's own chance of this, stated with the estimate: 10%; at least 1.7-fold (0.24 log units) between middle value and limit.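

Compound 4, like compound 1, gives only a limit and not a number in this assay, so no step can be read from compound 1 to compound 4. The compounds shown leave open how strongly compound 4 inhibits, and whether (3-fluorophenyl)amino in place of piperidin-1-yl changes inhibition at all.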